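A few compounds are considered here, and "the series" means these few. Any claim that something is new, unique, unknown or untested is made for them only; others in the source may bear on it.

Among the compounds with values here, compound 2 `CC(C)CC1CNCCN1c1ccc2[nH]ncc2c1` gives 15.9 nM in an assay on HEK293 cells for displacement of a labelled ligand from sodium-dependent dopamine transporter (Homo sapiens), read by scintillation proximity assay (on this read-out lower numbers stand for stronger inhibition and higher numbers for weaker inhibition), the lowest of the two numbers measured so far; compound 1 `c1ccc(C2CNCCN2c2ccc3[nH]ncc3c2)cc1` gives 200 nM. The step of a 13-fold lower number from compound 1 to compound 2 (1.10 log units; beyond the scatter) brought the number down strongly. Compound 3 `c1cc2[nH]ncc2cc1N1CCNCC1CC1CCCCC1` differs from compound 2 by cyclohexyl in place of isopropyl on a saturated chain carbon bound to a saturated ring carbon. Within the data shown here, no measured step covers this change directly; the step from compound 1 to compound 2 shows only the gain of isobutyl over phenyl on that ring carbon. The expected step is therefore a 1.3-fold higher number from compound 2 to compound 3 (0.10 log units; within the scatter), within the scatter, in this assay. The estimate for compound 3 is 20 nM, between 6 nM and 65 nM.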

Compound 3, inhibition constant: 316 nM
For compound 3 the middle estimate is 16-fold (1.20 log units) below the measured one; the whole stated range lies below it.
By their numbers in this assay, from the lowest: compound 2; then compounds 1 and 3 (each within the scatter of the next).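

Isobutyl's gain over phenyl on the saturated ring carbon does not carry over to every saturated group: putting cyclohexyl in place of isopropyl on the saturated chain carbon gives a 20-fold higher number from compound 2 to compound 3 (1.30 log units; beyond the scatter) in this assay and loses that gain. Cyclohexylmethyl and phenyl on that ring carbon are level, with a 1.6-fold higher number from compound 1 to compound 3 (0.20 log units; within the scatter) as the printed difference in this assay and no order between them. Going by these compounds, whether cyclopropylmethyl or a longer open chain would keep the low number of compound 2 stays open. Nothing measured here explains the loss.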